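A Methoxy Group Repeated on a Second Core

A few compounds are considered here, and "the series" means these few. Any claim that something is new, unique, unknown or untested is made for them only; others in the source may bear on it.

Measured compounds in a functional assay on MCF7 cells (Homo sapiens) for antiproliferative activity, read by MTT assay, with a stated time of 48 h; a higher number here means a weaker inhibitor, a lower number a stronger inhibitor:
compound 1, `COc1ccc(/C=C/C(=O)Nc2cc3c(Nc4ccc(Cl)c(Cl)c4)ncnc3s2)cc1`, gives 20100 nM
compound 2, `O=C(/C=C/c1ccccc1)Nc1cc2c(Nc3ccc(Cl)c(Cl)c3)ncnc2s1`, gives 15300 nM
compound 3, `O=C(/C=C/c1ccccc1)Nc1cc2ncnc(Nc3ccc(F)c(Cl)c3)c2s1`, gives 30900 nM

Compound 1 differs from compound 2 by methoxy in place of hydrogen on an aromatic carbon, and this change gave a 1.3-fold higher number from compound 2 to compound 1 (0.12 log units; within the scatter). Compound 3 carries a different core from compound 2; the difference between the two cores is not broken down here, and their values in this assay differ beyond the scatter. Compound 4, `COc1ccc(/C=C/C(=O)Nc2cc3ncnc(Nc4ccc(F)c(Cl)c4)c3s2)cc1`, has not been measured. It differs from compound 3 by methoxy in place of hydrogen on an aromatic carbon, the same change that was made from compound 2 to compound 1, and it occurs twice among these compounds. Because the earlier step was a 1.3-fold higher number from compound 2 to compound 1 (0.12 log units; within the scatter), compound 4 is expected to change from compound 3 by about a 1.3-fold higher number from compound 3 to compound 4 (0.11 log units; within the scatter). Compound 4 is therefore estimated at 40000 nM, from 15000 nM to 100000 nM.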

Compound 4, half-maximal inhibitory concentration: 29100 nM
The estimate for compound 4 lay 1.4-fold (0.14 log units) above the measured number; the measured number falls inside the stated range.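

In this assay, methoxy in place of hydrogen on an aromatic carbon gave a 1.1-fold lower number from compound 3 to compound 4 (0.03 log units; within the scatter), so on this second core the change again left the number within the scatter. The two steps agree across the two cores: the same change on two cores in this assay, a 1.3-fold higher number (0.12 log units; within the scatter) from compound 2 to compound 1 and a 1.1-fold lower number (0.03 log units; within the scatter) from compound 3 to compound 4, 1.4-fold (0.14 log units) apart, within the scatter of two such steps. Going by these compounds alone, this shows only that a change too small to read on one core stayed too small to read on the other; it does not show that a change with a clear effect would carry across these cores, or that the agreement would extend to any further core.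

The compounds shown leave open whether a different group in the same place, such as a hydroxyl, an amine or a carboxylic acid, would shift the number on either core. They also leave open whether a step beyond the scatter would be the same size on both cores.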